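Chloro to methoxy on the N-aryl ring of the core

The source may report more compounds than this note shows. Statements on the series, on what has been measured and on what is new or still open speak of the compounds shown alone.

Measured compounds in a functional assay on A549 cells (Homo sapiens) for inhibition, read by MTT assay, with a stated time of 72 h; on this read-out lower numbers stand for stronger inhibition and higher numbers for weaker inhibition:
- compound 1, `O=C(Nc1ccc(Oc2ccnc3[nH]ccc23)cc1)c1cn(-c2ccc(C(F)(F)F)cc2Cl)c2ccccc2c1=O`, gives 2350 nM
- compound 2, `Cn1ccc2c(Oc3ccc(NC(=O)c4cn(-c5ccc(Cl)cc5)c5ccccc5c4=O)cc3F)ccnc21`, gives 250 nM

Among the measured compounds shown here, compound 2 holds the lower of the two numbers, and the gap to compound 1 lies beyond the scatter; no single-point step between them is defined, so the two values are noted as they stand. Compound 3, `COc1ccc(-n2cc(C(=O)Nc3ccc(Oc4ccnc5c4ccn5C)c(F)c3)c(=O)c3ccccc32)cc1`, differs from compound 2 by methoxy in place of chloro on an aromatic carbon. For the measured compounds named here, no step of this kind has been measured, so the step from compound 2 to compound 3 is expected to be small, near the scatter, with a slight lean toward a higher number: a 1.6-fold higher number from compound 2 to compound 3 (0.20 log units; within the scatter). Compound 3 is expected to give 400 nM, within 150 nM to 1200 nM, in this assay.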

Compound 3, half-maximal inhibitory concentration: 3210 nM
Compound 3: the middle estimate sits 8.0-fold (0.90 log units) below what was measured; measured number above the stated range.
By their numbers in this assay, from the lowest: compound 2; then compounds 1 and 3 (each within the scatter of the next).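

In this assay, among the compounds shown here, the change from 4-chlorophenyl to 4-methoxyphenyl gives the first single-place step, and it is large: a 13-fold higher number from compound 2 to compound 3 (1.11 log units; beyond the scatter). The aromatic carbon para to a large group is therefore sensitive to what it carries, with chloro giving the lower number in this one pair. Nothing at hand accounts for the size of this step.

A single pair cannot show whether the step follows from chloro leaving or from methoxy entering. A methyl group or an amine on the same carbon would bear on that question.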